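Lengthening the Chain on Compound 3: Expected Cytotoxicity

This account rests on a few compounds, and the source may have more. Where it says the series, first, only, none or still open, it means among the compounds named here.

Of the compounds shown here, three have been measured in a functional assay on U-937 cells (Homo sapiens) for cytotoxicity, read by MTT assay, with a stated time of 24 h; a lower number here means a stronger inhibitor, a higher number a weaker inhibitor. Compound 1 `CCCCCCCCCCn1cc(-c2nc3ccccc3cc2CCCC)nn1` gives 25.2 ug/mL. Compound 2 `Cc1cc2ccccc2nc1-c1cn(CCC(F)(F)C(F)(F)C(F)(F)C(F)(F)C(F)(F)C(F)(F)C(F)(F)C(F)(F)F)nn1` gives 56.6 ug/mL in this assay. Compound 3 `Cc1cc2ccccc2nc1-c1cn(-c2ccc(F)cc2)nn1` gives 65.6 ug/mL. Among these three numbers compound 3 stands highest; its gap to compound 2 is within the usual scatter, so these two cannot be ordered, while its gap to compound 1 lies beyond the scatter, so compound 1 gives the lower number of that pair.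

Compound 4 `CCCc1cc2ccccc2nc1-c1cn(-c2ccc(F)cc2)nn1` has not yet been measured. It differs from compound 3 in one place: ethyl in place of hydrogen on a saturated chain carbon bound to an aromatic carbon. Going by the values given here, no pair of measured compounds that differ in one place is available, so the size of such a step cannot be read from a measured one.

The expectation therefore rests on little. Among the compounds with values here, compound 1, the one measured compound carrying a longer chain on the saturated chain carbon bound to an aromatic carbon, gives 25.2 ug/mL, a lower number than compound 3, but it also differs from compound 3 elsewhere, so its number is no clean guide. The step of a 1.5-fold lower number from compound 3 to compound 4 (0.16 log units; within the scatter) is expected to be modest, toward a lower number, and may not clear the scatter. Compound 4 is thus estimated at 45 ug/mL, with a range from 20 ug/mL to 100 ug/mL.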

Compound 4, half-maximal inhibitory concentration: 67.4 ug/mL
The estimate for compound 4 lay 1.5-fold (0.18 log units) below the measured number; measured number inside the range.
By their numbers in this assay, from the lowest: compound 1; then compounds 2, 3 and 4 (each within the scatter of the next).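

In this assay, going by these compounds alone, the step of a 1.0-fold higher number from compound 3 to compound 4 (0.01 log units; within the scatter) is the first one that can be read at this position. It places ethyl in place of hydrogen on a saturated chain carbon bound to an aromatic carbon, which, cut one bond further out, reads as methyl to propyl, and it stays within the scatter, so this change at this place does not separate the two compounds in this assay. No measurement at hand bears on why the number holds across this change.

The compounds shown leave open whether a longer chain such as octyl, or a chain ending in an amine or a carboxylic acid, would move the number beyond the scatter at this place. Within the data shown here, whether the same step reads alike when the rest of the molecule differs also stays open, and only this one pair differing in one place is at hand to speak to it.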